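The compounds below may be only part of what the source reports. "The series", "measured", "known", "first", "only" and "open" are said of these compounds alone.

Measured in an ADME assay on HepG2 2.2.15 cells (Homo sapiens) for cytotoxicity, read by MTT assay, with stated times of 48 h and 9 days; a higher number here means that more compound is tolerated, a lower number that less compound is tolerated:
compound 1 `COc1ccc2c(=O)c(/C=C/C(=O)Nc3cccc(Cl)c3)coc2c1`: 1100000 nM
compound 2 `COc1ccc2c(=O)c(/C=C/C(=O)NCc3ccccc3)coc2c1`: 376000 nM
compound 3 `COc1ccc2c(=O)c(/C=C/C(=O)Nc3ccccc3Cl)coc2c1`: 1010000 nM

Compound 1 gives the highest number of the three, with compound 3 within the scatter of it; compound 2 stands clearly lower, and a 2.7-fold higher number from compound 2 to compound 3 (0.43 log units; beyond the scatter) reverses that gap. Compound 4 `COc1ccc2c(=O)c(/C=C/C(=O)NCc3ccc(F)cc3)coc2c1` awaits measurement in this assay. Its change from compound 1 is 4-fluorobenzyl in place of 3-chlorophenyl on an amide-type nitrogen. For the measured compounds named here, the one measured step of this kind is a 2.9-fold lower number from compound 1 to compound 2 (0.47 log units; beyond the scatter), a modest drop; no measured step shows what the fluorine adds on a benzyl group. A comparable modest drop is therefore expected for compound 4, a 2.8-fold lower number from compound 1 to compound 4 (0.44 log units; beyond the scatter). The estimate for compound 4 is 400000 nM, with a range from 200000 nM to 900000 nM.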

Compound 4, half-maximal cytotoxic concentration: 133000 nM
Beside the measured number, compound 4's estimate is 3.0-fold (0.48 log units) above it; measured number below the stated range.
By their numbers in this assay, from the lowest: compound 4; then compound 2; then compounds 3 and 1 (each within the scatter of the next).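

In this assay, fluoro in place of hydrogen on an aromatic carbon of the benzyl group gives a 2.8-fold lower number from compound 2 to compound 4 (0.45 log units; beyond the scatter), so a substituent on that group moves the number beyond the scatter. The gap to the chlorophenyl amides widens to an 8.3-fold lower number from compound 1 to compound 4 (0.92 log units; beyond the scatter) and a 7.6-fold lower number from compound 3 to compound 4 (0.88 log units; beyond the scatter), leaving the 4-fluorobenzyl amide lowest of the four. Nothing available accounts for this drop.

Going by these compounds, whether chloro, methoxy or a carboxylic acid on the benzyl group lowers the number likewise stays open. So does the effect of a longer chain between the amide nitrogen and the aromatic ring.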